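The compounds below may be only part of what the source reports. "The series", "measured", "known", "first", "only" and "open" are said of these compounds alone.

Measured compounds in a functional assay on HL-60 cells (Homo sapiens) for cytotoxicity, read by MTT assay; on this read-out lower numbers stand for stronger inhibition and higher numbers for weaker inhibition:

- compound 1, `N#Cc1c(Nc2ccccc2)c(Cl)c2nc(N)nc(N)c2c1F`, gives 47 ug/mL
- compound 2, `N#Cc1c(Nc2ccccc2)c(F)c2nc(N)nc(N)c2c1F`, gives 40 ug/mL
- compound 3, `CCCCNc1c(C#N)c(NCCCC)c2c(N)nc(N)nc2c1Cl`, gives 0.7 ug/mL

Compound 1 and compound 2 share a core and differ in one place: fluoro in place of chloro on an aromatic carbon. The step of a 1.2-fold lower number from compound 1 to compound 2 (0.07 log units; within the scatter) is small and within the scatter, so the two values are treated as equivalent in this assay.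

Compound 3 sits on a different core, carrying two butylamino groups where the compounds above carry an anilino group. How the two cores differ is not broken down here; what the values show is that compound 3 gives the lowest number of the three, beyond the scatter against both compound 1 and compound 2.

Compound 4, `CCCCNc1c(C#N)c(NCCCC)c2c(N)nc(N)nc2c1F`, is not yet measured. It differs from compound 3 by fluoro in place of chloro on an aromatic carbon. This is the same kind of change as that from compound 1 to compound 2, but the surroundings are not identical: in compound 3 the changed carbon is ortho to a butylamino group and para to a butylamino group, whereas in compound 1 it is ortho to an anilino group and para to a fluoro group.

Going by the values given here, because a 1.2-fold lower number from compound 1 to compound 2 (0.07 log units; within the scatter) lies within the scatter, the expectation for compound 4 is a step of similar size, a 1.2-fold lower number from compound 3 to compound 4 (0.07 log units; within the scatter), resting on the single precedent only. Compound 4 is therefore estimated to give 0.6 ug/mL in this assay, with an expected range from 0.3 ug/mL to 1.4 ug/mL.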

Compound 4, half-maximal inhibitory concentration: 1.4 ug/mL
The estimate for compound 4 lay 2.3-fold (0.37 log units) below the measured number; the measured number falls inside the stated range.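

In this assay, fluoro in place of chloro on the core of compound 3 gives a 2.0-fold higher number from compound 3 to compound 4 (0.30 log units; within the scatter), so this exchange on the aromatic carbon leaves no reading beyond the scatter on this core either. Set beside the earlier step, the exchange does not separate the two cores: the same change on two cores in this assay, a 1.2-fold lower number (0.07 log units; within the scatter) from compound 1 to compound 2 and a 2.0-fold higher number (0.30 log units; within the scatter) from compound 3 to compound 4, 2.4-fold (0.37 log units) apart, within the scatter of two such steps. Going by these compounds alone, this supports carrying the chloro-to-fluoro exchange between these two cores as a change with no resolved effect in this assay, even though the surroundings of the changed carbon differ, but it rests on only two matched pairs and does not show that the same would hold on any other core or explain why the steps are small.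

The compounds shown leave open whether a bromo group, a methoxy group or a plain hydrogen on this carbon would read like chloro and fluoro, and whether anything larger at this place would be accepted. They also leave open whether the exchange stays this small with a shorter or longer alkylamino chain in place of butylamino, or on a core carrying one butylamino group and one anilino group.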